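Swapping a hydroxyphenyl for dichlorophenyl on the core

The source may report more compounds than this note shows. Statements on the series, on what has been measured and on what is new or still open speak of the compounds shown alone.

Three compounds have been measured in a functional assay, with a stated time of 20 min, tested at 2 uM; on this read-out lower numbers stand for a weaker effect and higher numbers for a stronger effect at the one concentration tested:

Compound 1, `COc1cc(/C=C/C(=O)C2=C(/C=C/c3ccc(O)c(OC)c3)NC(=O)NC2c2ccc(C)cc2)ccc1O`: 15.5%
Compound 2, `COc1cc(/C=C/C(=O)C2=C(/C=C/c3ccc(O)c(OC)c3)NC(=O)NC2c2ccccc2O)ccc1O`: 29.9%
Compound 3, `COc1cc(/C=C/C(=O)C2=C(/C=C/c3ccc(O)c(OC)c3)NC(=O)NC2c2ccc(O)cc2)ccc1O`: 33.3%

Compound 3 gives the highest of the three numbers, but its gap to compound 2 lies within the scatter, so the two cannot be ranked; only its gap to compound 1 is real, a number 17.8 percentage points higher from compound 1 to compound 3 (beyond the scatter). The next compound, compound 4, `COc1cc(/C=C/C(=O)C2=C(/C=C/c3ccc(O)c(OC)c3)NC(=O)NC2c2c(Cl)cccc2Cl)ccc1O`, differs from compound 3 in one place: 2,6-dichlorophenyl in place of 4-hydroxyphenyl on a saturated ring carbon.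

Within the data shown here, two measured steps bear on this change. Both hydroxy-bearing rings gave more than the plain methyl-bearing ring of compound 1: a number 14.4 percentage points higher from compound 1 to compound 2 (beyond the scatter) and a number 17.8 percentage points higher from compound 1 to compound 3 (beyond the scatter), while a number 3.4 percentage points higher from compound 2 to compound 3 (within the scatter). Compound 4 carries a ring with no hydroxy at all, which puts it closer to compound 1 than to compound 3. A modest fall in this assay is therefore expected, a number 15.3 percentage points lower from compound 3 to compound 4 (beyond the scatter). For compound 4 the estimated activity is 18%, with a range from 8% to 32%.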

Compound 4, a percentage reported as activity, at one concentration (the size of the read-out at that concentration, not a potency): 11.2%
Beside the measured number, compound 4's estimate is 6.8 percentage points above it, and the stated range covers the measured number.
By their numbers in this assay, from the lowest: compounds 4 and 1 (each within the scatter of the next); then compounds 2 and 3 (each within the scatter of the next).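

In this assay the 2,6-dichlorophenyl ring on this saturated ring carbon falls clearly short of both hydroxy-bearing rings, with a number 22.1 percentage points lower from compound 3 to compound 4 (beyond the scatter) and a number 18.7 percentage points lower from compound 2 to compound 4 (beyond the scatter) as the two gaps. Against the 4-methylphenyl ring there is a number 4.3 percentage points lower from compound 1 to compound 4 (within the scatter) and so no real separation, which means that the two rings without a hydroxy now sit together and both lie under the two rings with one. That split among these four compounds holds for two quite different hydroxy-free rings, not only for the methyl-bearing one, and nothing at hand explains it.

The compounds shown leave open whether a hydroxy is specifically needed on this ring, or whether a methoxy or an amine in its place would give similar numbers. They also leave open how a plain phenyl ring or a ring bearing a single chlorine would compare.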